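Cytotoxicity notes on compounds 1 to 4

This account rests on a few compounds, and the source may have more. Where it says the series, first, only, none or still open, it means among the compounds named here.

Compound 1 `c1ccc(-c2ccc(Cn3cncc3CNc3ccc(-c4ccc[nH]4)c(-c4ccccc4)c3)cc2)cc1` — in a toxicity assay on NIH3T3 cells (Mus musculus) for cytotoxicity, read by resazurin assay (on this read-out lower numbers stand for an effect already at smaller amounts and higher numbers for an effect only at larger amounts of compound), compound 1 gives only a limit, > 10000 nM.
Compound 2 `O=C(OC1CCCCC1)c1ccc(NCc2cncn2Cc2ccc(-c3ccccc3)cc2)cc1-c1ccccc1` — in this assay compound 2 gives only a limit, > 10000 nM.
Compound 3 `c1ccc(-c2ccc(Cn3cncc3CNc3ccc(N4CCCCC4)c(-c4ccccc4)c3)cc2)cc1` — in this assay compound 3 gives only a limit, > 1000 nM.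

Compound 3 stands at the limit of > 1000 nM in this assay, at which 1 of the 3 values shown sits. The two other compounds sit at the limit of > 10000 nM in this assay, at which 2 of the 3 values shown sit. Because all three values are limits, the steps a step that the two limits leave unreadable from compound 1 to compound 2, a step that the two limits leave unreadable from compound 1 to compound 3 and a step that the two limits leave unreadable from compound 2 to compound 3 cannot be read, so no size of effect has been resolved anywhere in the series.

Compound 4 `CNC(=O)c1ccc(NCc2cncn2Cc2ccc(-c3ccccc3)cc2)cc1-c1ccccc1` is the next compound for this assay. It differs from compound 3 as follows: methylcarbamoyl in place of piperidin-1-yl on an aromatic carbon. Within the data shown here, none of the measured steps gives a readable size, so no step beyond the scatter can be expected from them. Given that compound 3 gives only a limit, compound 4 is expected to give a similar outcome, an expected step that the limit leaves unreadable from compound 3 to compound 4. The estimate for compound 4 in this assay is 20000 nM, with a range from 3000 nM to 100000 nM, and most likely the assay again reports only a limit.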

Compound 4, half-maximal effective concentration: > 1000 nM
Compound 4 was reported as a limit; the forecaster's own chance of this, stated with the estimate: 80%; the middle value lies beyond the limit too.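

In this assay compound 4 gives > 1000 nM as a limit only. None of the steps from compound 1, compound 2 or compound 3 to compound 4 can be read. The compounds shown leave open where the half-maximal effective concentration of any of them lies, and whether exchanging these groups changes it at all.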